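A few compounds are considered here, and "the series" means these few. Any claim that something is new, unique, unknown or untested is made for them only; others in the source may bear on it.

The series rests on a shared core, seen in its simplest form in compound 1 `CN(C)CN1C(=O)C(=O)c2c(Br)cccc21` and compound 3 `CCN(CC)CN1C(=O)C(=O)c2c(Br)cccc21`. In a functional assay on MCF7 cells (Homo sapiens) for cytotoxicity, read by sulforhodamine B assay, with a stated time of 48 h (on this read-out lower numbers stand for stronger inhibition of growth and higher numbers for weaker inhibition of growth), compound 1 gives 57600 nM, and compound 3 gives 20200 nM. For the measured compounds named here, the one step that can be read between them, a 2.9-fold lower number from compound 1 to compound 3 (0.46 log units; beyond the scatter), shows that a larger amine on that chain carbon went with a lower number.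

Compound 2 `Cc1ccc2nc(/N=C3\C(=O)N(CN4CCCCC4)c4cccc(Br)c43)sc2c1` carries a further group on the core and a piperidin-1-yl on the chain carbon. In this assay compound 2 gives 39100 nM, a number that lies within the usual scatter of both compound 1 and compound 3, so no ordering among the three can be claimed from it.

Compound 4 `Cc1ccc2nc(/N=C3\C(=O)N(CN(C)C)c4cccc(Br)c43)sc2c1` differs from compound 2 in one place: dimethylamino in place of piperidin-1-yl on a saturated chain carbon bound to an amide-type nitrogen in a ring. Going by the values given here, this runs the opposite way to the only measured step in this part of the molecule, where the amine grew rather than shrank. Since the step from compound 1 to compound 3 was modest and only just beyond the scatter, a comparable move in the other direction is expected here, so compound 4 is estimated to give a somewhat higher number than compound 2, by about a 1.7-fold higher number from compound 2 to compound 4 (0.22 log units; within the scatter). For compound 4 the estimate in this assay is 65000 nM, between 25000 nM and 170000 nM.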

Compound 4, concentration for 50% growth inhibition: 18000 nM
Compound 4: the middle estimate sits 3.6-fold (0.56 log units) above what was measured; the measured number lies below the stated range.
By their numbers in this assay, from the lowest: compounds 4, 3, 2 and 1 (each within the scatter of the next, the first and the last beyond it).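

On the core that carries the further group, the amine on the saturated chain carbon bound to the amide-type nitrogen in a ring does change the result in this assay: with dimethylamino in place of piperidin-1-yl, there is a 2.2-fold lower number from compound 2 to compound 4 (0.34 log units; beyond the scatter), a modest step beyond the scatter. The earlier compounds shown here showed only a larger amine going with a lower number, in a 2.9-fold lower number from compound 1 to compound 3 (0.46 log units; beyond the scatter), whereas here the amine with fewer heavy atoms, and with no ring, goes with the lower number, so across these two steps the count of heavy atoms on the chain carbon does not set one direction. Nothing available here gives a reason for this change.

The compounds shown leave open whether the opposite directions of the two steps come from the further group on the core or from the difference between a ring amine and an open-chain amine. Diethylamino on the core of compound 2, or a pyrrolidin-1-yl or morpholin-4-yl on the chain carbon of either core, would bear on that question.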